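The source may report more compounds than this note shows. Statements on the series, on what has been measured and on what is new or still open speak of the compounds shown alone.

Measured in a physicochemical assay for solubility, using the shake flask method, with a stated time of 24 h, at pH 2; on this read-out lower numbers stand for lower solubility and higher numbers for higher solubility:
- compound 1 `O=c1ncn(Cc2ccc(F)cc2)c2ccc(Oc3ncccc3C(F)(F)F)cc12`: 4.5 ug/mL
- compound 2 `COc1ccc2c(c1)c(=O)ncn2Cc1ccc(F)cc1F`: > 900 ug/mL

Compound 2 stands at > 900 ug/mL, which is a limit of the assay and not a number. Compound 3 `O=c1ncn(Cc2ccc(F)cc2F)c2ccc(Oc3ccncc3C(F)(F)F)cc12` carries 3-(trifluoromethyl)pyridin-4-yl in place of methyl on an oxygen on an aromatic ring of compound 2 (3-(trifluoromethyl)pyridin-4-yl in place of methyl on an oxygen on an aromatic ring). Compound 1, which also has a trifluoromethyl-bearing ring on such an oxygen, gives 4.5 ug/mL, and this points to a large fall for compound 3. The expected change in this assay is a large downward step, an at least 36-fold lower number from compound 2 to compound 3 (1.55 log units; beyond the scatter). The estimate for compound 3 is 25 ug/mL, with an expected range from 5 ug/mL to 150 ug/mL.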

Compound 3, solubility: 700 ug/mL
The estimate for compound 3 lay 28-fold (1.45 log units) below the measured number, and the stated range ends below it.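

In this assay, compound 3 shows that the oxygen on the aromatic ring can carry 3-(trifluoromethyl)pyridin-4-yl in place of methyl and still give 700 ug/mL. The change is an at least 1.2-fold lower number from compound 2 to compound 3 (0.10 log units; that floor lies within the scatter), so only a small floor on the fall can be read. Its true size stays unknown because the starting value of compound 2 is a limit of the assay and not a number: the limit of > 900 ug/mL in this assay, at which 1 of the 3 values shown sits.

The compounds shown leave open whether an unsubstituted phenyl ring or a chain ending in an amine on the same oxygen would give a similar number.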